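The source may report more compounds than this note shows. Statements on the series, on what has been measured and on what is new or still open speak of the compounds shown alone.

Compound 3, with the structure `Cc1nc(N[C@H](C)c2ccccc2)nc(N[C@@H]2C[C@H](CO)[C@@H](O)[C@H]2O)c1-c1nc2cnccc2s1`, is tested in an ADME assay on cells (Homo sapiens) for cytotoxicity, read by polymerase chain reaction, with a stated time of 3 days (a higher number here means that more compound is tolerated, a lower number that less compound is tolerated), where compound 3 gives 25000 nM. Compound 2, `Cc1nc(NCc2ccccc2)nc(N[C@@H]2C[C@H](CO)[C@@H](O)[C@H]2O)c1-c1nc2cnccc2s1`, gives 25000 nM in this assay, level with compound 3 at the digits shown, and the two stand together at the top of the three numbers. Compound 1, `CNc1nc(C)c(-c2nc3cnccc3s2)c(N[C@@H]2C[C@H](CO)[C@@H](O)[C@H]2O)n1`, gives 14000 nM; the gap to compound 3 is a 1.8-fold higher number from compound 1 to compound 3 (0.25 log units; within the scatter). The other measured steps are a 1.8-fold higher number from compound 1 to compound 2 (0.25 log units; within the scatter) and no change at the digits printed from compound 2 to compound 3 (within the scatter), so every step among these three compounds stays within the scatter.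

Compound 4, `Cc1nc(N[C@H](C)c2ccc(F)cc2)nc(N[C@@H]2C[C@H](CO)[C@@H](O)[C@H]2O)c1-c1nc2cnccc2s1`, differs from compound 3 by fluoro in place of hydrogen on an aromatic carbon. For the measured compounds named here, none of the measured steps touches the six-membered aromatic ring of carbon only; they all change the group on the nitrogen, and none of them moved the number beyond the scatter. No step for a fluoro in place of hydrogen exists among these compounds. The expectation for compound 4 is therefore a step of about no change at the digits printed from compound 3 to compound 4 (within the scatter), that is none beyond the scatter. The estimated value for compound 4 in this assay is 25000 nM, with a range from 12000 nM to 50000 nM.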

Compound 4, half-maximal cytotoxic concentration: 25000 nM
The estimate for compound 4 equals the measured number at the digits printed; low and high end bracket the measured number.
By their numbers in this assay, from the lowest: compounds 1, 2, 3 and 4 (each within the scatter of the next).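

In this assay, for the compounds shown here, fluoro on an aromatic carbon of the six-membered aromatic ring of carbon only, para to a large group, leaves the reading unmoved (no change at the digits printed from compound 3 to compound 4 (within the scatter)), and this is the only step here that alters that ring rather than the group on the nitrogen. Changing the whole group on the nitrogen to 1-(4-fluorophenyl)ethyl also stays inside the normal spread of repeat measurements, whether it replaces benzyl (no change at the digits printed from compound 2 to compound 4 (within the scatter)) or methyl (a 1.8-fold higher number from compound 1 to compound 4 (0.25 log units; within the scatter)). No supporting measurement bears on this result.

From the compounds shown here alone, it remains open whether an amine, a carboxylic acid or a methoxy group at that same ring carbon would also leave the reading unmoved. Fluoro at a different carbon of this ring is equally open.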